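The source may report more compounds than this note shows. Statements on the series, on what has been measured and on what is new or still open speak of the compounds shown alone.

The shared core of compound 1 `COc1cc(-c2nnc(SCC(=O)c3ccc(F)cc3)n2N)cc(OC)c1OC` carries a trimethoxyphenyl and a thioether-linked ketone, and in a functional assay on HepG2 cells (Homo sapiens) for antiproliferative activity, read by MTT assay, with a stated time of 48 h (on this read-out higher numbers stand for weaker inhibition and lower numbers for stronger inhibition), compound 1 gives 90400 nM. Compound 2 `COc1ccc(C(=O)CSc2nnc(-c3cc(OC)c(OC)c(OC)c3)n2N)cc1` differs by a methoxy in place of fluoro on an aromatic carbon; in this assay compound 2 reaches only the limit of > 100000 nM, which is a limit and not a number. Compound 3 `COc1cc(-c2nnc(SCC(=O)Nc3ccccc3F)n2N)cc(OC)c1OC` carries a (2-fluorophenyl)amino in place of the 4-fluorophenyl on the carbonyl carbon, and in this assay compound 3 gives 18700 nM, the lowest of the two numbers shown. That change is a 4.8-fold lower number from compound 1 to compound 3 (0.68 log units; beyond the scatter), and measured from the limit of compound 2 it is an at least 5.3-fold lower number from compound 2 to compound 3 (0.72 log units; beyond the scatter). The step between the two ketones, an at least 1.1-fold higher number from compound 1 to compound 2 (0.04 log units; that floor lies within the scatter), lies within the scatter.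

Compound 4 `COc1cc(-c2nnc(SCC(=O)NCc3ccc(Cl)cc3)n2N)cc(OC)c1OC` keeps the amide of compound 3 but carries 4-chlorobenzyl in place of 2-fluorophenyl on an amide-type nitrogen. Among the measured compounds shown here, none of the measured steps alters the group on the amide nitrogen: the two steps reaching compound 3 concern the exchange of a ketone for an amide, and the one step among the ketones stayed within the scatter. With nothing closer to draw on, the writer expects for compound 4 a step of no more than modest size in this assay, a 1.5-fold higher number from compound 3 to compound 4 (0.18 log units; within the scatter). Compound 4 is therefore estimated at 28000 nM, within 8000 nM to 90000 nM.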

Compound 4, half-maximal inhibitory concentration: > 100000 nM
Compound 4: only a limit was reported (the forecaster's own chance of this, stated with the estimate: 15%); middle value at least 3.5-fold (0.55 log units) from the limit.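

Among the compounds shown here, the group on the amide nitrogen, which no earlier step had touched, proves to matter in this assay: with 4-chlorobenzyl in place of 2-fluorophenyl, the result is an at least 5.3-fold higher number from compound 3 to compound 4 (0.72 log units; beyond the scatter). Holding the amide is therefore not enough to hold the lower number of compound 3, and the comparison with the ketone gives an at least 1.1-fold higher number from compound 1 to compound 4 (0.04 log units; that floor lies within the scatter), so at the floor that can be read, this amide is not separated from compound 1. The step between compound 2 and compound 4 cannot be read, because both stand at a limit and not at a number: the limit of > 100000 nM in this assay, at which 2 of the 4 values shown sit.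

The change to 4-chlorobenzyl alters several things at once, since the ring moves one carbon away from the amide nitrogen while chlorine replaces fluorine and the halogen's place on the ring differs, and the compounds shown do not tell which of these carries the step. As far as these compounds go, a 4-chlorophenyl or a 2-fluorobenzyl on the amide nitrogen would separate these changes, and how an unsubstituted phenyl or a cyclohexyl would read there remains open.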